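From 2-carboxyethenyl to 2-acetylethenyl on a shared core

The source may hold more compounds than are shown below. What is called first, only, known or untested is meant among the compounds shown, and "the series" means these compounds.

Numbers so far in an ADME assay on MT2 cells (Homo sapiens) for cytotoxicity, read by XTT assay, with a stated time of 4 days (on this read-out lower numbers stand for higher toxicity in this test and higher numbers for lower toxicity in this test), are as follows.
compound 1 `Cc1cc(Br)cc(C)c1Oc1ccc([N+](=O)[O-])c(Nc2ccc(C#N)cc2)n1` gives 65100 nM
compound 2 `Cc1cc(/C=C/C(=O)O)cc(C)c1Oc1ccc([N+](=O)[O-])c(Nc2ccc(C#N)cc2)n1` gives 34800 nM

With only these two numbers, compound 2 (34800 nM) lies within the scatter of compound 1 (65100 nM). Compound 3 `CC(=O)/C=C/c1cc(C)c(Oc2ccc([N+](=O)[O-])c(Nc3ccc(C#N)cc3)n2)c(C)c1` differs from compound 2 in one place: methyl in place of hydroxy on a carbonyl carbon, which turns 2-carboxyethenyl into 2-acetylethenyl. Within the data shown here, only one measured step bears on this, and it is indirect: 2-carboxyethenyl in place of bromo on an aromatic carbon gave a 1.9-fold lower number from compound 1 to compound 2 (0.27 log units; within the scatter). No measurement covers the exchange of hydroxy for methyl itself. On that thin evidence, no step beyond the scatter is expected in this assay, in either direction. The expected change is a 1.2-fold lower number from compound 2 to compound 3 (0.06 log units; within the scatter). Compound 3 is estimated at 30000 nM (11000 nM to 80000 nM).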

Compound 3, half-maximal cytotoxic concentration: > 47900 nM
Compound 3: no number, only a limit; the forecaster's own chance of this, stated with the estimate: 15%; middle value at least 1.5-fold (0.20 log units) from the limit.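

Compound 3 gives no number in this assay, only a limit: the limit of > 47900 nM in this assay, at which 1 of the 3 values shown sits. Among these compounds, this is the first direct reading of methyl in place of hydroxy on a carbonyl carbon, and it gives an at least 1.3-fold higher number from compound 2 to compound 3 (0.13 log units; that floor lies within the scatter), so on this evidence turning 2-carboxyethenyl into 2-acetylethenyl brings no lower number in this test, although the floor of the step does not clear the scatter. The step from compound 1 to compound 3 cannot be read.

On these data alone, how far the true value of compound 3 lies from its limit remains open, and so does the full size of the step from compound 2. Also open, as far as these compounds go, is how this assay would respond to an amide or a methyl ester on the same carbonyl carbon, or to a longer chain in place of the ethenyl link.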